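Moving the fluorine on the benzoyl ring: rat exposure

The source may report more compounds than this note shows. Statements on the series, on what has been measured and on what is new or still open speak of the compounds shown alone.

Measured compounds:
compound 1, `O=C(O)CCC(=O)N(C1CC1)[C@H]1c2ccccc2N(C(=O)c2cccc(OC(F)(F)F)c2)[C@H]2CC[C@H]21`: 156 ng.h/mL
compound 2, `O=C(O)CCC(=O)N(C1CC1)[C@H]1c2ccccc2N(C(=O)c2cccc(F)c2)[C@H]2CC[C@H]21`: 131 ng.h/mL

In an ADME assay on the whole organism for pharmacokinetics, with Rattus norvegicus as the target, with a stated time of 6 h, at a dose of 0.5 mg/kg by the intravenous route (on this read-out higher numbers stand for higher exposure at the dose given and lower numbers for lower exposure), compound 1 gives 156 ng.h/mL, and compound 2 gives 131 ng.h/mL. Within the data shown here, compound 2 sits at the lower end of these two numbers, yet the only measured step between them, a 1.2-fold lower number from compound 1 to compound 2 (0.08 log units; within the scatter), is within the scatter, so the two compounds cannot be separated on this read-out.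

Compound 3, `O=C(O)CCC(=O)N(C1CC1)[C@H]1c2ccccc2N(C(=O)c2ccc(F)cc2)[C@H]2CC[C@H]21`, differs from compound 2 by 4-fluorophenyl in place of 3-fluorophenyl on a carbonyl carbon. Among the measured compounds shown here, no measured step concerns this kind of change: the one step available swapped a whole group for another rather than moving a fluorine around the ring, so it offers no direct guide. With nothing pointing either way, the expectation for compound 3 is a step of a 1.0-fold lower number from compound 2 to compound 3 (0.00 log units; within the scatter), that is, no change beyond the scatter. Compound 3 is therefore estimated at 130 ng.h/mL, with a range from 60 ng.h/mL to 280 ng.h/mL.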

Compound 3, area under the concentration-time curve: 201 ng.h/mL
Compound 3: the middle estimate sits 1.5-fold (0.19 log units) below what was measured; low and high end bracket the measured number.
By their numbers in this assay, from the lowest: compounds 2, 1 and 3 (each within the scatter of the next).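

Moving the fluorine, with 4-fluorophenyl in place of 3-fluorophenyl on the carbonyl carbon, gives a 1.5-fold higher number from compound 2 to compound 3 (0.19 log units; within the scatter) in this assay, so the position of the fluorine on this ring makes no difference that can be told from the scatter. Replacing the larger 3-(trifluoromethoxy)phenyl group with 4-fluorophenyl reads the same way, at a 1.3-fold higher number from compound 1 to compound 3 (0.11 log units; within the scatter), so these three aromatic groups on the carbonyl carbon cannot be separated on this read-out. No accompanying measurement is available to explain these numbers.

The compounds shown leave open whether an amine or a nitrile on this aromatic ring would take the exposure beyond the scatter. They also leave open what a pyridine ring would do in place of the fluorinated phenyl ring.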